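The source may hold more compounds than are shown below. What is called first, only, known or untested is meant among the compounds shown, and "the series" means these compounds.

Compound 1 `CSc1nc(NCCCCNc2ccnc3cc(Cl)ccc23)c(C#N)c(-c2cccc([N+](=O)[O-])c2)n1`: 1100 nM in an ADME assay on HeLa cells (Homo sapiens) for inhibition, read by cell counting; a lower number here means a stronger inhibitor, a higher number a weaker inhibitor
Compound 2 `CSc1nc(-c2ccc([N+](=O)[O-])cc2)c(C#N)c(N2CCN(c3ccnc4cc(Cl)ccc34)CC2)n1`: 228000 nM in this assay

Of these two numbers compound 1 has the lower one; compound 2 lies far higher, a gap well beyond the usual scatter, but the two structures differ in more than one place, so no single step can be read from them. Compound 3 `COc1ccc(-c2nc(SC)nc(NCCCCNc3ccnc4cc(Cl)ccc34)c2C#N)cc1` arises from compound 1 by 4-methoxyphenyl in place of 3-nitrophenyl on an aromatic carbon. Within the data shown here, no measured pair shows this change, so its direction is unknown; a step of modest size, only a little beyond the scatter, is expected in this assay. Compound 3 is expected to give 2000 nM, in a range from 500 nM to 8000 nM. The estimate means an expected 1.8-fold higher number from compound 1 to compound 3 (0.26 log units; within the scatter) that is small against the uncertainty.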

Compound 3, half-maximal inhibitory concentration: 3400 nM
Compound 3: the middle estimate sits 1.7-fold (0.23 log units) below what was measured, within the range that was stated.
By their numbers in this assay, from the lowest: compound 1; then compound 3; then compound 2.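

In this assay, among these compounds, this is the first single change that can be read: at the aromatic carbon ortho to a cyano group, 4-methoxyphenyl in place of 3-nitrophenyl gives a 3.1-fold higher number from compound 1 to compound 3 (0.49 log units; beyond the scatter). The position is therefore not indifferent to the group it carries, although the step is modest. Nothing available explains this step.

The change alters both the substituent and its place on the phenyl ring, so the two cannot be separated here. On these data alone, how a 3-methoxyphenyl group or an unsubstituted phenyl would compare at this position remains open.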